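The source may hold more compounds than are shown below. What is called first, only, known or untested is meant among the compounds shown, and "the series" means these compounds.

Compound 1 `CCO/C(O)=C1\C(COCCNc2n[nH]c(N)n2)=NC(C)=C(C(=O)OC)C1c1cccc(Cl)c1Cl` is the starting point. In a functional assay (aorta) with Rattus norvegicus as the target (a higher number here means a weaker inhibitor, a lower number a stronger inhibitor), compound 1 gives 6.31 nM, the lowest of the three numbers measured here. Its closest neighbour is compound 3 `CCO/C(O)=C1\C(COCCNc2n[nH]c(O)n2)=NC(C)=C(C(=O)OC)C1c1cccc(Cl)c1Cl`, which in this assay gives 10 nM; the step of a 1.6-fold higher number from compound 1 to compound 3 (0.20 log units; within the scatter) lies within the scatter, so the two cannot be ranked. Compound 2 `CCOC(=O)NC(=S)NCCOCC1=C(C(=O)OCC)C(c2cccc(Cl)c2Cl)/C(=C(\O)OC)C(C)=N1`, built on a different tail, gives 31.6 nM in this assay, a clearly higher number than compound 1.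

Compound 4 `CCO/C(O)=C1\C(COCCNc2cc(O)ncn2)=NC(C)=C(C(=O)OC)C1c1cccc(Cl)c1Cl` is not yet measured. It differs from compound 1 in one place: 6-hydroxypyrimidin-4-yl in place of 5-amino-1H-1,2,4-triazol-3-yl on an amine nitrogen. Going by the values given here, the only measured step that touches this part of the molecule is the one from compound 1 to compound 3, where hydroxy in place of amino on an aromatic carbon left the number essentially unchanged. Among the compounds with values here, no measured pair shows what exchanging the five-membered ring for a six-membered one does, so the expectation is uncertain. Compound 4 is expected to stay close to compound 1, with the step of a 1.6-fold higher number from compound 1 to compound 4 (0.20 log units; within the scatter) estimated to be small. Compound 4 is therefore estimated at 10 nM, with a likely range from 3 nM to 40 nM.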

Compound 4, half-maximal inhibitory concentration: 1.26 nM
Estimate against measurement, compound 4: 7.9-fold (0.90 log units) above; measured number below the stated range.
By their numbers in this assay, from the lowest: compound 4; then compounds 1 and 3 (each within the scatter of the next); then compound 2.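

Going by these compounds alone, on the amine nitrogen, the identity of the ring matters more than the earlier compounds suggested: in this assay, 6-hydroxypyrimidin-4-yl in place of 5-amino-1H-1,2,4-triazol-3-yl gives a 5.0-fold lower number from compound 1 to compound 4 (0.70 log units; beyond the scatter), whereas exchanging amino for hydroxy on the five-membered ring gave a step within the scatter. The same six-membered ring in place of 5-hydroxy-1H-1,2,4-triazol-3-yl gives a 7.9-fold lower number from compound 3 to compound 4 (0.90 log units; beyond the scatter), so the lower number appears from both five-membered rings. No measurement available here explains why this exchange lowers the number.

Whether the gain comes from the ring or from its hydroxy group stays open, since neither 6-aminopyrimidin-4-yl nor an unsubstituted pyrimidin-4-yl group appears among these compounds. From the compounds shown here alone, how a longer chain carrying 6-hydroxypyrimidin-4-yl would behave also remains open.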